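The source may report more compounds than this note shows. Statements on the series, on what has been measured and on what is new or still open speak of the compounds shown alone.

Measured compounds:
compound 1, `CCOC(=O)NCCCOc1cc2c(-n3nc(-c4ccccn4)nc3N)ncnc2cc1OC`, 800 nM
compound 2, `CCCCCCOC(=O)NCCCOc1cc2c(-n3nc(-c4ccccn4)nc3N)ncnc2cc1OC`, 28600 nM

Among the measured compounds shown here, compound 2 stands highest of the two numbers in an assay on MCF7 cells for inhibition of Serine-protein kinase ATM (Homo sapiens), read by immunofluorescence, with a stated time of 1 h (a lower number here means a stronger inhibitor, a higher number a weaker inhibitor), with compound 1 its only neighbour at a 36-fold higher number from compound 1 to compound 2 (1.55 log units; beyond the scatter). Compound 3, `COc1cc2ncnc(-n3nc(-c4ccccn4)nc3N)c2cc1OCCCNC(=O)OCC(C)(C)C`, carries the change (tert-butyl in place of pentyl on a saturated chain carbon bound to an oxygen next to a carbonyl group). For the measured compounds named here, only the step from compound 1 to compound 2 bears on it: there, adding chain length on the same carbamate raised the number greatly. Compound 3 removes part of that length, so a lower number is expected for compound 3, about a 5.7-fold lower number from compound 2 to compound 3 (0.76 log units; beyond the scatter), falling short of compound 1. Compound 3 is estimated at 5000 nM, within 1500 nM to 16000 nM.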

Compound 3, half-maximal inhibitory concentration in the Serine-protein kinase ATM assay: 1900 nM
Compound 3: middle estimate off by 2.6-fold (0.42 log units), on the high side; low and high end bracket the measured number.
By their numbers in the Serine-protein kinase ATM assay, from the lowest: compound 1; then compound 3; then compound 2.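

In the Serine-protein kinase ATM assay, tert-butyl in place of pentyl wins back most of what the longer chain lost, a 15-fold lower number from compound 2 to compound 3 (1.18 log units; beyond the scatter). Only a modest gap remains to the shorter chain, a 2.4-fold higher number from compound 1 to compound 3 (0.38 log units; beyond the scatter), so a larger group at this place does not have to cost as much as the hexyl carbamate did. The gain comes with lower solubility: the measured solubility of compound 2, 1000 nM, and of compound 3, 200 nM, a 5.0-fold lower number (0.70 log units; beyond the scatter) In a physicochemical assay for solubility, in phosphate buffer, with a stated time of 18 h, at pH 7.4 (on this read-out higher numbers stand for higher solubility and lower numbers for lower solubility), compound 2 gives 1000 nM and compound 3 gives 200 nM.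

Branching and shortening happen together in this change, so the two cannot be told apart. A straight butyl chain or an isopropyl group at this place would begin to separate them.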